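The compounds below may be only part of what the source reports. "The series", "measured", "known", "first", "only" and "open" are said of these compounds alone.

Compound 1, `CSc1nc(NCCCCCO)c2ccccc2n1`: 49900 nM
Compound 2, `COc1ccc(CNc2nc(SC)nc3ccccc23)cc1`: 85600 nM

Of the compounds shown here, two of this set have been tested in an ADME assay on 184B5 cells (Homo sapiens) for cytotoxicity, read by MTT assay, with a stated time of 72 h; a higher number here means a weaker inhibitor of growth, a lower number a stronger inhibitor of growth. In this assay compound 1 gives 49900 nM, and compound 2 gives 85600 nM. For the measured compounds named here, compound 1 carries the lowest of the two numbers, but its nearest neighbour, compound 2, lies close enough that the gap between them falls within the scatter, so the two values show only that both compounds sit at much the same level. The two structures differ in more than one place, and nothing further can be read from the pair.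

Compound 3, `CSc1nc(NCCCc2ccccc2)c2ccccc2n1`, has not yet been measured in this assay. It departs from compound 1 in one place: phenyl in place of 2-hydroxyethyl on a saturated chain carbon, three bonds along the chain from a nitrogen on an aromatic ring. Going by the values given here, no measured pair in the set isolates this change, so there is no precedent to lean on. The expected step is small, a 1.2-fold lower number from compound 1 to compound 3 (0.10 log units; within the scatter), and is expected to stay within the scatter, with at most a slight drift toward a lower number. Because compound 1 gives 49900 nM in this assay, compound 3 is expected to give 40000 nM, with a range from 15000 nM to 100000 nM.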

Compound 3, concentration for 50% growth inhibition: 6770 nM
Compound 3: middle estimate off by 5.9-fold (0.77 log units), on the high side; the whole stated range lies above it.
By their numbers in this assay, from the lowest: compound 3; then compounds 1 and 2 (each within the scatter of the next).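

In this assay, phenyl in place of 2-hydroxyethyl on a saturated chain carbon, three bonds along the chain from a nitrogen on an aromatic ring, gives a 7.4-fold lower number from compound 1 to compound 3 (0.87 log units; beyond the scatter), so the number responds to what the end of this chain carries, something the first two compounds, which differ in more than one place, could not show. The change removes a group with no ring, one hydrogen-bond donor and one hydrogen-bond acceptor, and brings in a larger group with one six-membered aromatic ring of carbon only and neither donor nor acceptor, and this single step cannot tell which of these differences matters. No measurement among the data shown accounts for the shift.

The compounds shown leave open whether the lower number comes from gaining the phenyl ring or from losing the hydroxyl, a question that a cyclohexyl group or a plain alkyl chain at the same place would help to separate. They also leave open how an amine or a carboxylic acid at the end of the chain, or a longer chain leading to the phenyl, would compare with compound 3.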